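The compounds below may be only part of what the source reports. "The series", "measured", "known", "first", "only" and "open" are said of these compounds alone.

Compound 1 `CC(C)OC(=O)N1CCC2(CC1)CC(CCCOc1ccc(S(C)(=O)=O)cc1)C2` gives 78 nM 
Compound 2 `CC(C)OC(=O)N1CCC2(CC1)CC(CCCOc1ccc(C(=O)NC3CC3)c(F)c1)C2` gives 8 nM 

Among the compounds with values here, in a functional assay on cells for agonist activity at Glucose-dependent insulinotropic receptor (Homo sapiens), read by HTRF and cAMP accumulation, with a stated time of 30 min (a higher number here means that more compound is needed for the effect, a lower number that less compound is needed), compound 2 stands at the lower of the two numbers measured so far. Compound 1 sits at 78 nM, a gap that lies beyond the usual scatter, so compound 2 is the more potent of the pair on this assay.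

Compound 3 `CC(C)OC(=O)N1CCC2(CC1)CC(CCCOc1ccc(C(=O)NCC(N)=O)c(F)c1)C2` follows from compound 2 by a single change: carbamoylmethyl in place of cyclopropyl on an amide-type nitrogen. Within the data shown here, no measured pair shows this particular exchange, so its effect is not known from the data. The expected outcome is a modest step upward in the number, that is a small loss of potency, of a size that may well fall within the scatter; the step from compound 2 to compound 3 is estimated at a 2.5-fold higher number from compound 2 to compound 3 (0.40 log units; beyond the scatter). Compound 3 is therefore expected to give about 20 nM, with a range from 6 nM to 70 nM.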

Compound 3, half-maximal effective concentration in the Glucose-dependent insulinotropic receptor assay: 48 nM
Compound 3: the middle estimate sits 2.4-fold (0.38 log units) below what was measured, and the stated range covers the measured number.
By their numbers in the Glucose-dependent insulinotropic receptor assay, from the lowest: compound 2; then compounds 3 and 1 (each within the scatter of the next).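

The exchange of cyclopropyl for carbamoylmethyl on the amide-type nitrogen gives, in the Glucose-dependent insulinotropic receptor assay, a 6.0-fold higher number from compound 2 to compound 3 (0.78 log units; beyond the scatter), so the group at this position bears on potency. Compounds 1 and 2 differ in more than one place and could not show this. The same change also moves solubility in the favourable direction, so here a loss of potency comes with a gain in a physicochemical assay for solubility, read by HPLC, in simulated intestinal fluid, with stated times of 2 h and 22 h, at 37 degrees C; on this read-out lower numbers stand for lower solubility and higher numbers for higher solubility: the measured solubility of compound 2, 8.58 ug/mL, and of compound 3, 18.4 ug/mL, a 2.1-fold higher number (0.33 log units; beyond the scatter). In the physicochemical assay compound 2 gives 8.58 ug/mL and compound 3 gives 18.4 ug/mL.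

A single exchange leaves open whether the loss of potency follows from the departure of the cyclopropyl ring or from the arrival of the carbamoylmethyl group. It also leaves open whether another group on this nitrogen, such as a hydroxyethyl chain, a carboxylic acid or an amine on a longer chain, would keep the potency of compound 2 while raising solubility.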